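Swapping bromo for cyano on the naphthalene-bearing sulfonamide

The source may report more compounds than this note shows. Statements on the series, on what has been measured and on what is new or still open speak of the compounds shown alone.

Compound 1, `Cc1cc(S(N)(=O)=O)ccc1NC(=O)COc1ccc(Cl)cc1Oc1ccc2cc(Br)ccc2c1`, in an ADME assay on C8166 cells (Homo sapiens) for cytotoxicity, read by MTT assay (on this read-out lower numbers stand for higher toxicity in this test and higher numbers for lower toxicity in this test), gives 31300 nM.
Compound 2, `Cc1cc(S(N)(=O)=O)ccc1NC(=O)COc1ccc(F)cc1Oc1ccc2cc(Br)ccc2c1`, gives in this assay only a limit of the assay, > 357000 nM.

Compound 2 therefore stands at the limit of > 357000 nM in this assay, at which 1 of the 2 values shown sits, so only a limit and no number is known for it. Compound 3, `Cc1cc(S(N)(=O)=O)ccc1NC(=O)COc1ccc(F)cc1Oc1ccc2cc(C#N)ccc2c1`, differs from compound 2 by cyano in place of bromo on an aromatic carbon. Among the compounds with values here, the only measured step, an at least 11-fold higher number from compound 1 to compound 2 (1.05 log units; beyond the scatter), concerns a change of the halogen on a different ring and does not bear on the exchange of bromo for cyano; no measured step speaks to it. With compound 2 at a limit, the step of an at least 1.1-fold lower number from compound 2 to compound 3 (0.07 log units; that floor lies within the scatter) is expected to stay within the scatter, and compound 3 is estimated at 300000 nM, in the range 80000 nM to 400000 nM, with a fair chance that the assay again reports only a limit.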

Compound 3, half-maximal cytotoxic concentration: > 395000 nM
Compound 3 ended at the assay's limit (the forecaster's own chance of this, stated with the estimate: 55%); middle value at least 1.3-fold (0.11 log units) from the limit.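

In this assay compound 2 and compound 3 each give only a limit of the assay and no number, so the step between them cannot be read. From the compounds shown here alone, whether cyano in place of bromo changes the toxicity in this test at all stays open.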